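A few compounds are considered here, and "the series" means these few. Any claim that something is new, unique, unknown or untested is made for them only; others in the source may bear on it.

Working notes on the series in a functional assay on MGC-803 cells (Homo sapiens) for inhibition, read by MTT assay, with a stated time of 48 h; on this read-out lower numbers stand for stronger inhibition and higher numbers for weaker inhibition. Compound 1 `COc1ccc(CNc2cc(OC)c(OC)c(OC)c2)cc1[N+](=O)[O-]` gives 19400 nM, compound 2 `COc1ccc(CNc2cc(OC)c(OC)c(OC)c2)cc1Cl` gives 46200 nM and compound 3 `COC(=O)c1cc(CNc2cc(OC)c(OC)c(OC)c2)ccc1OC` gives 49600 nM. For compound 3, the gap to its nearest neighbour is a 1.1-fold higher number from compound 2 to compound 3 (0.03 log units; within the scatter), and the gap to its furthest is a 2.6-fold higher number from compound 1 to compound 3 (0.41 log units; beyond the scatter).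

Next is compound 4 `COc1ccc(CNc2cc(OC)c(OC)c(OC)c2)cc1F`, not yet measured. The change is fluoro in place of methoxycarbonyl on an aromatic carbon, ortho to a methoxy group and meta to a large group.

For the measured compounds named here, no fluoro compound has a number yet, so the evidence is indirect. Chloro and methoxycarbonyl at this carbon cannot be told apart, as the step of a 1.1-fold higher number from compound 2 to compound 3 (0.03 log units; within the scatter) shows. Only nitro stands apart, with a 2.4-fold higher number from compound 1 to compound 2 (0.38 log units; beyond the scatter) as the matching step to chloro. Three compounds support no firm trend, and compound 1 goes against any claim that the substituent at this carbon is without effect. Compound 2, with 46200 nM, is the closest guide, since chloro is the substituent nearest to fluoro in kind.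

No step beyond the scatter is therefore expected, and the expected step is a 1.2-fold lower number from compound 3 to compound 4 (0.07 log units; within the scatter). For compound 4 the estimated value is 42000 nM, with an expected range of 20000 nM to 85000 nM.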

Compound 4, half-maximal inhibitory concentration: 39700 nM
For compound 4 the middle estimate is 1.1-fold (0.02 log units) above the measured one; the range from low to high includes it.
By their numbers in this assay, from the lowest: compound 1; then compounds 4, 2 and 3 (each within the scatter of the next).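

In this assay, replacing methoxycarbonyl with fluoro on this aromatic carbon removes the double bond and both hydrogen-bond acceptors of the leaving group, yet the result is only a 1.2-fold lower number from compound 3 to compound 4 (0.10 log units; within the scatter), and replacing chloro with fluoro gives a 1.2-fold lower number from compound 2 to compound 4 (0.07 log units; within the scatter). The position therefore tolerates three quite different groups without a readable change, and compound 1 is the one exception to this pattern, since the comparison with nitro gives a 2.0-fold higher number from compound 1 to compound 4 (0.31 log units; beyond the scatter), a second step out of the nitro compound that lies beyond the scatter, though a modest one. No measured evidence is at hand to explain why nitro stands apart from fluoro, chloro and methoxycarbonyl here.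

From the compounds shown here alone, it remains open whether an amine, a carboxylic acid, a hydroxyl group or a longer chain on this carbon would sit with compound 2, compound 3 and compound 4 or with compound 1, and what plain hydrogen there would give. All four compounds share the same core and are read only in this assay, so the series does not show whether the gap to nitro persists when another part of the core changes.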